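A few compounds are considered here, and "the series" means these few. Any claim that something is new, unique, unknown or untested is made for them only; others in the source may bear on it.

Compound 1, `CCc1ccc(NC2=CC(=O)c3nc4n(c3C2=O)[C@H]2OC[C@@H](O)[C@H]2OC4)cc1`, gives 3080 nM in a functional assay on ECa-109 cells for inhibition, with ECa-109 cell line (Homo sapiens) as the target, read by sulforhodamine B assay; a higher number here means a weaker inhibitor, a lower number a stronger inhibitor.
Compound 2, `CCCc1ccc(NC2=CC(=O)c3nc4n(c3C2=O)[C@H]2OC[C@@H](O)[C@H]2OC4)cc1`, gives only a limit of this assay, > 4000 nM.
Compound 3, `CCOc1ccccc1NC1=CC(=O)c2nc3n(c2C1=O)[C@H]1OC[C@@H](O)[C@H]1OC3`, gives 4630 nM.

Among the two plain numbers, compound 1 has the lowest, and its nearest neighbour is compound 3, with a 1.5-fold higher number from compound 1 to compound 3 (0.18 log units; within the scatter). Moving from compound 1 to compound 2 gives an at least 1.2-fold higher number from compound 1 to compound 2 (0.11 log units; that floor lies within the scatter), so that comparison rests on the limit of > 4000 nM in this assay, at which 1 of the 3 values shown sits, and says little. The two measured steps therefore only swap one aryl group for another on the amine nitrogen, and neither moves beyond the scatter.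

Compound 4, `CCCN(CCC)C1=CC(=O)c2nc3n(c2C1=O)[C@H]1OC[C@@H](O)[C@H]1OC3`, differs from compound 1 in a larger way: dipropylamino in place of (4-ethylphenyl)amino on a double-bonded ring carbon. No measured step covers the loss of the aromatic ring and of the hydrogen-bond donor, so the direction cannot be read from the steps shown; all that can be said is that the measured compounds sit close together at weak inhibition. Compound 4 is expected to give 6000 nM, within a range from 2500 nM to 20000 nM. This estimate means a 1.9-fold higher number from compound 1 to compound 4 (0.29 log units; within the scatter).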

Compound 4, half-maximal inhibitory concentration: > 16000 nM
Compound 4 was reported as a limit; the forecaster's own chance of this, stated with the estimate: 55%; at least 2.6-fold (0.42 log units) between middle value and limit.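

Putting dipropylamino in place of (4-ethylphenyl)amino on this double-bonded ring carbon gives an at least 5.1-fold higher number from compound 1 to compound 4 (0.71 log units; beyond the scatter) in this assay. Within the data shown here, this shows that the position does respond to a change of group, whereas the one fully readable earlier step, a swap of one aryl group for another on the amine nitrogen, stayed within the scatter. Compound 4 was reported only as a limit, so the true size of the step is unknown: the limit of > 16000 nM in this assay, at which 1 of the 4 values shown sits.

This change removes the aromatic ring and the amine hydrogen together, so the compounds shown cannot tell which loss matters. Propylamino, which keeps the amine hydrogen without the ring, and methyl(4-ethylphenyl)amino, which keeps the ring without that hydrogen, would pull the two apart.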